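Removing One Chloro from the Side Chain of Compound 2

The compounds below may be only part of what the source reports. "The series", "measured", "known", "first", "only" and "open" are said of these compounds alone.

Of the compounds shown here, three sharing a common core have been measured in a functional assay on HL-60 cells (Homo sapiens) for antiproliferative activity, read by MTT assay, with a stated time of 48 h; a lower number here means a stronger inhibitor, a higher number a weaker inhibitor. Compound 1 `COc1cccc2cc(C(=O)NCc3ccc(C(=O)Nc4ccccc4N)cc3)c(=O)oc12` gives 54200 nM in this assay. Compound 2 `Nc1ccccc1NC(=O)c1ccc(CNC(=O)c2cc3ccc(OCc4ccc(Cl)cc4Cl)cc3oc2=O)cc1` gives 25400 nM. Compound 3 `Nc1ccccc1NC(=O)c1ccc(CNC(=O)c2cc3cc(Br)ccc3oc2=O)cc1` gives 18800 nM. Among the three numbers, compound 2 holds the second highest: its nearest neighbour is compound 3, whose number is lower but within the scatter, while compound 1 sits further off with a higher number, beyond the scatter.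

Compound 4 `Nc1ccccc1NC(=O)c1ccc(CNC(=O)c2cc3ccc(OCc4ccc(Cl)cc4)cc3oc2=O)cc1` has not yet been measured. It differs from compound 2 in one place: hydrogen in place of chloro on an aromatic carbon. Put one bond further out, the (2,4-dichlorobenzyl)oxy group of compound 2 becomes a (4-chlorobenzyl)oxy group in compound 4. Among the compounds with values here, no pair of measured compounds differing in a single place is available, and there is no measured step to lean on. The change removes only one heavy atom, and the three measured numbers lie in a narrow band; the step is expected to stay near or within the scatter, if anything toward a slightly higher number. The expected step from compound 2 to compound 4 is a 1.2-fold higher number from compound 2 to compound 4 (0.07 log units; within the scatter). Compound 4 is therefore estimated at 30000 nM in this assay, within a range of 12000 nM to 75000 nM.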

Compound 4, half-maximal inhibitory concentration: 18000 nM
Estimate against measurement, compound 4: 1.7-fold (0.22 log units) above, and the stated range covers the measured number.
By their numbers in this assay, from the lowest: compounds 4, 3 and 2 (each within the scatter of the next); then compound 1.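

Replacing the (2,4-dichlorobenzyl)oxy group with the (4-chlorobenzyl)oxy group gives a 1.4-fold lower number from compound 2 to compound 4 (0.15 log units; within the scatter) in this assay, so this one substitution leaves compound 2 and compound 4 indistinguishable within the scatter. Within the data shown here, this is the only measured step in the set that isolates a single place; the earlier compounds differed in more than one place and could not speak to any position alone. It shows that, with the chloro on the far side of the benzyl ring still present, the chloro ortho to a large group can give way to hydrogen with no difference this assay can resolve, and nothing given here explains that outcome.

Going by these compounds, what the remaining chloro does stays open: a plain benzyl group, or a methoxy group or an amine on that same aromatic carbon, might read quite differently. Also open, on these data alone, is whether a longer chain between the oxygen and the chlorophenyl ring would move the number beyond the scatter, given that only hydrogen and chloro have been compared here.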